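The compounds below may be only part of what the source reports. "The series", "measured", "known", "first", "only" and "open" are said of these compounds alone.

Measured so far:
- compound 1, `COc1ccc(/C=C/c2cc(=O)cco2)cc1`: 710 uM
- compound 2, `COc1ccc(C2CC(=O)C=CO2)cc1`: 264 uM
- compound 3, `COc1ccc(C2CC(=O)C(Br)=CO2)cc1`: 164 uM

All three numbers come from an ADME assay on HaCaT cells (Homo sapiens) for inhibition, read by sulforhodamine B assay, with a stated time of 48 h; on this read-out higher numbers stand for weaker inhibition of growth and lower numbers for stronger inhibition of growth. Compound 3 gives the lowest of the three; its gap to compound 2 lies within the scatter, while its gap to compound 1 lies beyond it, so compound 3 is only clearly separated from compound 1.

Compound 4, `COc1ccc(C2CC(=O)C(I)=CO2)cc1`, is the next step from compound 3: iodo in place of bromo on a double-bonded ring carbon. Within the data shown here, one measured step touches the same ring carbon: a 1.6-fold lower number from compound 2 to compound 3 (0.21 log units; within the scatter). Among the measured compounds shown here, no measured step swaps one halogen for another. On that basis the step is expected to stay within the scatter, with no clear direction: a 1.2-fold lower number from compound 3 to compound 4 (0.07 log units; within the scatter). Compound 4 is therefore estimated at 140 uM, expected to fall between 60 uM and 330 uM.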

Compound 4, concentration for growth inhibition (reported as GI): 53.3 uM
Compound 4: middle estimate off by 2.6-fold (0.42 log units), on the high side; measured number below the stated range.
By their numbers in this assay, from the lowest: compound 4; then compounds 3 and 2 (each within the scatter of the next); then compound 1.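

Among these compounds, at this double-bonded ring carbon, the choice of halogen matters: iodo in place of bromo gives a 3.1-fold lower number from compound 3 to compound 4 (0.49 log units; beyond the scatter) and is the first change at this position to go beyond the scatter. Measured against hydrogen, iodo gives a 5.0-fold lower number from compound 2 to compound 4 (0.69 log units; beyond the scatter), whereas bromo's step from hydrogen stayed within the scatter. Nothing available here explains this difference between the two halogens.

The compounds shown leave open how chloro, a methyl group or an amine would behave at this carbon. They also leave open whether iodo would have a similar effect on the core of compound 1.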